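The source may hold more compounds than are shown below. What is called first, only, known or untested is meant among the compounds shown, and "the series" means these compounds.

Compound 1, `COc1ccc(N(C)C(=O)N(C)c2cc(OC)c(OC)c(OC)c2)cc1`, in a functional assay on ONS-76 cells (Homo sapiens) for cytotoxicity, read by MTT assay, with a stated time of 72 h (on this read-out higher numbers stand for weaker inhibition and lower numbers for stronger inhibition), gives >= 125000 nM, a limit of the assay rather than a number.

Compound 2, `COc1cc(N(C)C(=O)N(C)c2ccc(F)cc2)cc(OC)c1OC`, gives >= 125000 nM, again a limit and not a number.

Compound 1 and compound 2 share one core and differ only in that the aromatic methoxy is replaced by fluoro; the step that the two limits leave unreadable from compound 1 to compound 2 cannot be read, because both values sit at the limit of >= 125000 nM in this assay, at which 2 of the 2 values shown sit. Where compound 2 stands is therefore known only as a limit.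

Compound 3, `COc1cc(N(C)C(=O)N(C)c2cccc([N+](=O)[O-])c2)cc(OC)c1OC`, is not yet measured. It differs from compound 2 by 3-nitrophenyl in place of 4-fluorophenyl on an amide-type nitrogen. For the measured compounds named here, no measured step bears on this change, since the only step available is unreadable. Compound 3 is therefore expected to remain at the same limit, with the estimate 125000 nM, between 30000 nM and 400000 nM. The expected step is a number no higher from compound 2 to compound 3 (the limit leaves the size open), none beyond the scatter.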

Compound 3, half-maximal inhibitory concentration: >= 125000 nM
Compound 3 gave a limit, no number; the forecaster's own chance of this, stated with the estimate: 75%; the middle value lies on the limit itself.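

For the compounds shown here, compound 3 gives >= 125000 nM as a limit of the assay and not a number, so no step linking it to compound 1 or compound 2 can be read: the limit of >= 125000 nM in this assay, at which 3 of the 3 values shown sit. In this assay the compounds shown leave open which change to the shared core, if any, would give a readable number.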